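Compound 1 to compound 4: bis(oxetanyl)amine in place of amine

The source may hold more compounds than are shown below. What is called first, only, known or untested is meant among the compounds shown, and "the series" means these compounds.

Compound 1 `NCCCCN(C[C@H]1Cc2ncccc2CN1)[C@H]1CCCc2cccnc21` sits second highest of the three numbers in an ADME assay for permeability, using PAMPA, with a stated time of 4 h, at pH 5.5 (a higher number here means that the compound crosses the layer faster, a lower number that the compound crosses the layer more slowly), giving 17 nm/s. Compound 3 `NC/C=C\CN(C[C@H]1Cc2ncccc2CN1)[C@H]1CCCc2cccnc21` gives 28 nm/s, and the step of a 1.6-fold higher number from compound 1 to compound 3 (0.22 log units; within the scatter). Compound 2 `NCCCCN(C[C@@H]1Cc2nccnc2CN1)[C@H]1CCCc2cccnc21` gives 2 nm/s; its two values against compound 1 show the largest gap among the measured compounds.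

Compound 4 `c1cnc2c(c1)CN[C@@H](CN(CCCCN(C1COC1)C1COC1)[C@H]1CCCc3cccnc31)C2` differs from compound 1 by a group of 9 heavy atoms (6 carbon, 1 nitrogen, 2 oxygen; 2 four-membered non-aromatic rings with 1 hetero atom each) in place of one nitrogen atom, on a saturated chain carbon, four bonds along the chain from an amine nitrogen. Among the measured compounds shown here, no measured step touches this position or this kind of exchange; the step from compound 1 to compound 3 concerns the chain itself, not its terminus. The expectation therefore rests on the structural change alone, and the estimated step is a 3.5-fold higher number from compound 1 to compound 4 (0.55 log units; beyond the scatter), upward but uncertain. Compound 4 is estimated at 60 nm/s, with a range from 15 nm/s to 200 nm/s.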

Compound 4, apparent permeability: 62 nm/s
The estimate for compound 4 lay 1.0-fold (0.01 log units) below the measured number; measured number inside the range.
By their numbers in this assay, from the lowest: compound 2; then compounds 1 and 3 (each within the scatter of the next); then compound 4.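

Replacing amino with the group of 9 heavy atoms, on a saturated chain carbon, four bonds along the chain from an amine nitrogen, gives a 3.6-fold higher number from compound 1 to compound 4 (0.56 log units; beyond the scatter) in this assay. The earlier step on this chain, a 1.6-fold higher number from compound 1 to compound 3 (0.22 log units; within the scatter), did not show a change of this size. Nothing measured here explains the step.

The compounds shown leave open whether the four-membered rings are needed for this step, or whether a dimethylamino group in the same place would give a similar number.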